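The source may hold more compounds than are shown below. What is called first, only, known or untested is meant among the compounds shown, and "the series" means these compounds.

Among the compounds with values here, in a functional assay on A549 cells (Homo sapiens) for inhibition, read by CCK-8 assay, with a stated time of 48 h (a lower number here means a stronger inhibitor, a higher number a weaker inhibitor), compound 2 `COc1cc(-c2ccnc3cc(-c4ccc5cc[nH]c5c4)nn23)cc(OC)c1OC` gives 170 nM, and this is the only actual number so far. Compound 1 `COc1cc(-c2cc3nccc(-c4cc(OC)c(OC)c(OC)c4)n3n2)cc(OC)c1OC` reads > 10000 nM, which is a limit of the assay and not a number. Within the data shown here, no measured step between the two compounds is available, so the size of any structural effect has to be judged from these two readings alone.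

Compound 3 `COc1ccc(-c2cc3nccc(-c4cc(OC)c(OC)c(OC)c4)n3n2)cc1` keeps the core of compound 2 and changes one group. It has 4-methoxyphenyl in place of 1H-indol-6-yl on an aromatic carbon of a five-membered aromatic ring with 2 nitrogen (4-methoxyphenyl in place of 1H-indol-6-yl on an aromatic carbon). The 1H-indol-6-yl group is thus lost, and compound 1 also lacks it, with its reading of > 10000 nM being a limit.

On that slender basis, the estimated step of a 7.1-fold higher number from compound 2 to compound 3 (0.85 log units; beyond the scatter) is expected to go beyond the scatter, towards a weaker inhibitor in this assay. A reading at the assay limit cannot be ruled out. For compound 3 the expected value is 1200 nM, with an estimated range of 250 nM to 8000 nM.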

Compound 3, half-maximal inhibitory concentration: 376 nM
Beside the measured number, compound 3's estimate is 3.2-fold (0.50 log units) above it; measured number inside the range.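

In this assay, 4-methoxyphenyl in place of 1H-indol-6-yl on an aromatic carbon gives a 2.2-fold higher number from compound 2 to compound 3 (0.34 log units; beyond the scatter), a modest step, though one beyond the scatter. The 1H-indol-6-yl group is therefore not required for a measurable reading at this position: compound 3 has neither its five-membered aromatic ring nor its hydrogen-bond donor, and still gives 376 nM. Compound 1 differs from compound 3 only at this position. Compound 1 reads > 10000 nM, which is a limit of the assay and not a number, so the step to it cannot be read, and the series holds just this one such reading: the limit of > 10000 nM in this assay, at which 1 of the 3 values shown sits.

The compounds shown do not separate the contribution of the methoxy group from that of the six-membered aromatic ring carrying it, a question that a plain phenyl group, or a phenyl group bearing a hydroxyl or an amine, would address. They also leave open why the substituents at this position give such different readings, as the data here contain no measurement that could explain the difference.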